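Swapping a pentyl chain for a fluorophenyl ring

The source may hold more compounds than are shown below. What is called first, only, known or untested is meant among the compounds shown, and "the series" means these compounds.

Measured so far:
compound 1 `CCCCCCCc1cn(C(c2ccccc2)c2cc3cc(Br)ccc3nc2OC)nn1` gives 4.42%
compound 2 `CCOC(=O)c1cn(C(c2ccccc2)c2cc3cc(Br)ccc3nc2OC)nn1` gives 16.1%
compound 3 `CCCCCc1cn(C(c2ccccc2)c2cc3cc(Br)ccc3nc2OC)nn1` gives 11.4%

All three share one core and differ only in the group on the five-membered ring with three nitrogens. Going by the values given here, in an ADME assay on PC-3 cells (Homo sapiens) for cytotoxicity, read by sulforhodamine B assay, with a stated time of 48 h, tested at 10 uM (a higher number here means more inhibition at the concentration tested (going by the name of the read-out), a lower number less inhibition), compound 3 gives 11.4%; its gaps to compound 2 and to compound 1 are both within the scatter, so no order among the three can be read from these numbers, apart from the step of a number 11.7 percentage points higher from compound 1 to compound 2 (beyond the scatter), which is the only change beyond the scatter.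

Compound 4 `COc1nc2ccc(Br)cc2cc1C(c1ccccc1)n1cc(-c2ccc(F)cc2)nn1` is not yet measured. It differs from compound 3 in one place: 4-fluorophenyl in place of pentyl on an aromatic carbon. Among the compounds with values here, no measured step involves an aromatic ring at this position. Within the data shown here, the steps that bear on it are a number 7 percentage points higher from compound 1 to compound 3 (within the scatter) and a number 4.7 percentage points lower from compound 2 to compound 3 (within the scatter), both within the scatter, and the modest rise from compound 1 to compound 2. The evidence therefore points to a small change at most, and a change of a number 3.6 percentage points higher from compound 3 to compound 4 (within the scatter) is expected. Compound 4 is estimated at 15%, within a range of 3% to 32%.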

Compound 4, a percentage reported as inhibition, at one concentration (the size of the read-out at that concentration, not a potency): 16.4%
Beside the measured number, compound 4's estimate is 1.4 percentage points below it, and the stated range covers the measured number.
By their numbers in this assay, from the lowest: compounds 1, 3, 2 and 4 (each within the scatter of the next, the first and the last beyond it).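

In this assay, 4-fluorophenyl brings the first aromatic ring to this carbon of the five-membered ring, and the steps of a number 5 percentage points higher from compound 3 to compound 4 (within the scatter) and a number 0.3 percentage points higher from compound 2 to compound 4 (within the scatter) show that it can stand in for pentyl or ethoxycarbonyl with no change that can be read. Going by these compounds alone, the one step that can be read here is a number 12 percentage points higher from compound 1 to compound 4 (beyond the scatter), which is modest and sets this ring apart from heptyl only. No measurement among these compounds offers an explanation for these numbers.

The compounds shown leave open what the fluorine itself contributes, a question that a plain phenyl at this carbon would address. They also leave open whether an amine or a carboxylic acid at this carbon would give a number clearly apart from these.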